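Phenyl for 3,4-difluorophenyl in compound 2

A few compounds are considered here, and "the series" means these few. Any claim that something is new, unique, unknown or untested is made for them only; others in the source may bear on it.

Within the data shown here, in a functional assay on A549 cells (Homo sapiens) for inhibition, read by MTT assay, with a stated time of 48 h (on this read-out higher numbers stand for weaker inhibition and lower numbers for stronger inhibition), compound 2 `Fc1ccc(/C=N/Nc2nc(-c3ccc(F)c(F)c3)cs2)cc1F` gives 8490 nM, the lowest of the three numbers so far. Compound 3 `COc1cc(/C=N/Nc2nc(-c3ccc(F)c(F)c3)cs2)cc(Br)c1OC` gives 21100 nM and compound 1 `COc1cc(/C=N/Nc2nc(-c3ccc(Br)cc3)cs2)cc(Br)c1OC` gives 52300 nM. Both gaps to compound 2 lie beyond the scatter.

The next compound is compound 4 `Fc1ccc(/C=N/Nc2nc(-c3ccccc3)cs2)cc1F`, with phenyl in place of 3,4-difluorophenyl on an aromatic carbon of the five-membered aromatic ring with 1 nitrogen and 1 sulfur: phenyl in place of 3,4-difluorophenyl on an aromatic carbon. The rest of compound 2 is unchanged.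

Among the measured compounds shown here, only one measured step touches this place: a 2.5-fold lower number from compound 1 to compound 3 (0.39 log units; beyond the scatter). It is modest and beyond the scatter, and there 3,4-difluorophenyl enters rather than leaves. For the measured compounds named here, its starting group is 4-bromophenyl, not phenyl, so it bears on the present change only indirectly, and no compound with phenyl at this place has been measured. A step of similar modest size towards a higher number is therefore expected in this assay, though a step within the scatter cannot be excluded. The expected step is a 1.6-fold higher number from compound 2 to compound 4 (0.22 log units; within the scatter). For compound 4 the estimated value is 14000 nM, with an expected range of 6000 nM to 32000 nM.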

Compound 4, half-maximal inhibitory concentration: 91400 nM
For compound 4 the middle estimate is 6.5-fold (0.81 log units) below the measured one; measured number above the stated range.
By their numbers in this assay, from the lowest: compound 2; then compound 3; then compounds 1 and 4 (each within the scatter of the next).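

In this assay removing the two fluorines of 3,4-difluorophenyl gives an 11-fold higher number from compound 2 to compound 4 (1.03 log units; beyond the scatter) and this large step is the only measured one with phenyl at this place, on an aromatic carbon of the five-membered ring. Among these compounds, the position thus responds far more strongly to this change than the only earlier step, the modest 2.5-fold lower number from compound 1 to compound 3 (0.39 log units; beyond the scatter) at the same place, could show, although that step starts from 4-bromophenyl and sits on a different remainder of the molecule. In both steps 3,4-difluorophenyl stands on the side of the lower number, and no compound shown goes against this, but it rests on only two pairs.

Open, going by these compounds, is whether 4-fluorophenyl, with its single fluorine, or a group such as trifluoromethyl-substituted phenyl or a pyridine ring at this place would keep the number near that of compound 2. Also open, on these data alone, is whether phenyl would give a step of this size on the remainder of compound 3, which carries the bromine and the two methoxy groups.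

No measurement at hand accounts for the size of this step.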